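Methoxyphenyl for Difluorophenyl on a Cytotoxicity Read-out

The source may hold more compounds than are shown below. What is called first, only, known or untested is meant among the compounds shown, and "the series" means these compounds.

Three compounds of one series were examined in a toxicity assay on HepG2 2.2.15 cells (Homo sapiens) for cytotoxicity, read by CCK-8 assay, with a stated time of 8 days; on this read-out lower numbers stand for higher toxicity in this test and higher numbers for lower toxicity in this test. Compound 1 `CCOC(=O)c1cn(-c2ccccc2F)nc1CC(C)C` carries an ester on the shared core. For compound 1 the result is a limit of the assay rather than a number, namely > 100000 nM (the limit of > 100000 nM in this assay, at which 1 of the 3 values shown sits). Compound 2 `CC(C)Cc1nn(-c2nccs2)cc1C(=O)NCc1ccc(F)cc1F` gives 83600 nM in this assay, and compound 3 `CC(C)Cc1nn(-c2cccc(F)c2)cc1C(=O)NCc1ccccc1` gives 85900 nM. Compound 2 holds the lowest of the two numbers, yet compound 3 lies within the usual scatter of it, so this assay does not tell the two apart.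

Compound 4 `COc1ccc(CNC(=O)c2cn(-c3nccs3)nc2CC(C)C)cc1` has not yet been measured. It differs from compound 2 in one place: 4-methoxyphenyl in place of 2,4-difluorophenyl on a saturated chain carbon bound to an amide-type nitrogen. Within the data shown here, no step between measured compounds covers this change, and the two measured numbers show no difference beyond the scatter, so no step beyond the scatter is expected in this assay in either direction. Compound 4 is expected to give about 90000 nM, within a range from 40000 nM to 200000 nM. The step of a 1.1-fold higher number from compound 2 to compound 4 (0.03 log units; within the scatter) that this estimate means is expected to stay within the scatter.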

Compound 4, half-maximal cytotoxic concentration: > 100000 nM
Compound 4 was reported as a limit; the forecaster's own chance of this, stated with the estimate: 40%; at least 1.1-fold (0.04 log units) between middle value and limit.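

Among these compounds, this is the first step that can be read at this place: 4-methoxyphenyl in place of 2,4-difluorophenyl on a saturated chain carbon bound to an amide-type nitrogen gives an at least 1.1-fold higher number from compound 2 to compound 4 (0.07 log units; that floor lies within the scatter) in this assay. Compound 4 gives a limit of the assay rather than a number: > 100000 nM. The exchange of the two fluorine atoms for a methoxy group, which adds one hydrogen-bond acceptor, thus brings no lower number, but the full size of the step cannot be read from a limit, and the floor does not separate the two compounds beyond the scatter: the limit of > 100000 nM in this assay, at which 2 of the 4 values shown sit.

The compounds shown leave open how an amine or a carboxylic acid on this phenyl ring would read. They also leave open whether a longer chain at this place would bring a lower number.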